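Pyrazolyl in Place of Pyrrolidinyl: An Estimate for Compound 3

The source may hold more compounds than are shown below. What is called first, only, known or untested is meant among the compounds shown, and "the series" means these compounds.

Measured compounds:
Compound 1 `Cc1cc(Cl)c(C(=O)NC(=O)Nc2nc3ccc(S(=O)(=O)C4CCN(C)CC4)cc3s2)cc1-n1cccn1`: 6100 nM
Compound 2 `CCOc1cc(Cl)c(C(=O)NC(=O)Nc2nc3ccc(CN4CCN(C)CC4)cc3s2)cc1N1CCCC1`: 13 nM

Of the compounds shown here, two have been measured in a functional assay on CHO cells for agonist activity at hydroxycarboxylic acid receptor 1 (Homo sapiens), read by cAMP accumulation; a lower number here means that less compound is needed, a higher number that more compound is needed for the effect. Compound 2 shows the lower of the two numbers; compound 1 gives a far higher number, a gap well beyond the scatter of the method. Since compound 1 and compound 2 differ in several places at once, only their two values can be compared, and no single change accounts for the gap.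

Compound 3 `CCOc1cc(Cl)c(C(=O)NC(=O)Nc2nc3ccc(CN4CCN(C)CC4)cc3s2)cc1-c1ccn[nH]1` has not yet been measured. It differs from compound 2 in one place: 1H-pyrazol-5-yl in place of pyrrolidin-1-yl on an aromatic carbon. Among the measured compounds shown here, no measured pair isolates this change, so its effect is not known from the data. Because compound 2 gives 13 nM, the starting point is a low number, and the author expects the change to compound 3 to cost some potency, with a step of a 4.6-fold higher number from compound 2 to compound 3 (0.66 log units; beyond the scatter) in this assay, larger than the scatter but far short of the gap to compound 1. The estimate for compound 3 in this assay is 60 nM, with a range from 10 nM to 400 nM.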

Compound 3, half-maximal effective concentration: 360 nM
Beside the measured number, compound 3's estimate is 6.0-fold (0.78 log units) below it; measured number inside the range.
By their numbers in this assay, from the lowest: compound 2; then compound 3; then compound 1.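

With compound 3 the series gains its first pair that differs in one place, and in this assay that pair gives a 28-fold higher number from compound 2 to compound 3 (1.44 log units; beyond the scatter) on exchanging the group on this aromatic carbon, ortho to an ethoxy group and para to a chloro group, which shows that the number is highly sensitive to what stands there. Pyrrolidin-1-yl and 1H-pyrazol-5-yl both have 5 heavy atoms and no net charge, so this large step comes with no change in those counts; the entering group is an aromatic ring with 2 hetero atoms and 1 hydrogen-bond donor, and the leaving group a non-aromatic ring with 1 hetero atom and 0 hydrogen-bond donors. Which of these differences carries the step cannot be told, and no measurement at hand speaks to a cause.

The compounds shown leave open how a 1-methylpyrazol-5-yl group, the same ring with a methyl on the nitrogen in place of the hydrogen, or an open-chain amine such as diethylamino would stand against compound 2 at 13 nM in this assay. Among the compounds shown here, they also leave open whether the step keeps its size on another core such as that of compound 1, as one pair gives only one reading.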